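Swapping Bromo for Dimethylamino on the Compound 1 Chain

This account rests on a few compounds, and the source may have more. Where it says the series, first, only, none or still open, it means among the compounds named here.

Values measured in a functional assay on HCT-8 cells (Homo sapiens) for antiproliferative activity, read by MTT assay, with a stated time of 48 h (a lower number here means a stronger inhibitor, a higher number a weaker inhibitor), are:
- compound 1 `COc1ccc(C(=O)c2ccc(OC)c3c2OC(C)(C)C=C3)c(NC(=O)CBr)c1` gives 3250 nM
- compound 2 `COc1ccc(C(=O)c2ccc3c(c2)C=CC(C)(C)O3)c(NC(=O)CN)c1` gives 490 nM
- compound 3 `CCNCC(=O)Nc1cc(OC)ccc1C(=O)c1ccc(OC)c2c1C=CC(C)(C)O2` gives 7890 nM

Compound 1 holds the second highest of these three numbers, so it is neither the strongest nor the weakest of the set. Its gaps to both other compounds lie beyond the usual scatter of repeat measurements: compound 2 has the lower number and compound 3 the higher one.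

Compound 4 `COc1ccc(C(=O)c2ccc(OC)c3c2OC(C)(C)C=C3)c(NC(=O)CN(C)C)c1` keeps the core of compound 1 and changes one group, with dimethylamino in place of bromo on a saturated chain carbon (dimethylamino in place of bromo on a saturated chain carbon bound to a carbonyl carbon). That carbon is bound to a carbonyl carbon.

Among the measured compounds shown here, no measured pair shows this change alone, so any forecast is rough. Compound 2 (490 nM) and compound 3 (7890 nM) both carry a nitrogen group on this chain but also differ elsewhere, and their values fall on opposite sides of compound 1, so they suggest no clear direction. No change beyond the scatter is therefore expected, and the estimated step is a 1.1-fold lower number from compound 1 to compound 4 (0.03 log units; within the scatter) in this assay with wide uncertainty.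

For compound 4 the expected value is 3000 nM (estimated range 700 nM to 11000 nM).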

Compound 4, half-maximal inhibitory concentration: 1590 nM
Estimate against measurement, compound 4: 1.9-fold (0.28 log units) above; the range from low to high includes it.
By their numbers in this assay, from the lowest: compound 2; then compound 4; then compound 1; then compound 3.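

In this assay, among the compounds shown here, the result gives a 2.0-fold lower number from compound 1 to compound 4 (0.31 log units; beyond the scatter), the only comparison here in which the group on the saturated chain carbon bound to a carbonyl carbon changes while the core of compound 1 stays the same. It shows that this position accepts dimethylamino, with 3 heavy atoms and 1 hydrogen-bond acceptor, in place of bromo, a single heavy atom, with a modest gain in antiproliferative activity rather than a loss. No measurement shown explains this gain, so its cause remains unknown.

A single step cannot show whether the gain comes from having an amine on this carbon or simply from losing bromo; a morpholine, a piperidine or a methoxy group on the same carbon of the core of compound 1 would help to separate these two readings. A longer chain between the carbonyl carbon and the dimethylamino group would also test whether the distance from the shared core matters at this position.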